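The source may report more compounds than this note shows. Statements on the series, on what has been measured and on what is new or still open speak of the compounds shown alone.

Among the measured compounds shown here, compound 2 `C=CCSc1nc(NC)c2ncn([C@H]3C[C@H](OP(=O)(O)O)[C@@H](COP(=O)(O)O)O3)c2n1` is one of two compounds measured in a functional assay on cell membranes for antagonist activity at P2Y purinoceptor 1 (Meleagris gallopavo) (on this read-out lower numbers stand for stronger inhibition and higher numbers for weaker inhibition), where compound 2 gives 475 nM. The other, compound 1 `CNc1nc(I)nc2c1ncn2[C@H]1C[C@H](OP(=O)(O)O)[C@@H](COP(=O)(O)O)O1`, gives 891 nM in this assay. Compound 2 holds the lower of the two numbers, but its gap to compound 1 lies within the scatter of repeated measurements, so the two cannot be ranked against each other. For the measured compounds named here, the only step measured so far, a 1.9-fold lower number from compound 1 to compound 2 (0.27 log units; within the scatter), exchanged an iodo group for allylsulfanyl on an aromatic carbon of the shared core.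

Compound 3 `CCCCCCSc1nc(NC)c2ncn([C@H]3C[C@H](OP(=O)(O)O)[C@@H](COP(=O)(O)O)O3)c2n1` has not yet been measured. It differs from compound 2 in one place: pentyl in place of vinyl on a saturated chain carbon bound to a sulfur. Going by the values given here, the chain on the sulfur thus grows, but no measured step touches that chain; the single step at hand altered a different group and stayed within the scatter. With nothing pointing either way, no change beyond the scatter is expected in this assay, and the expected step is a 1.1-fold higher number from compound 2 to compound 3 (0.02 log units; within the scatter). Compound 3 is therefore estimated at 500 nM, within a range from 150 nM to 1700 nM.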

Compound 3, half-maximal inhibitory concentration: 3370 nM
The estimate for compound 3 lay 6.7-fold (0.83 log units) below the measured number, outside the stated range (above it).
By their numbers in this assay, from the lowest: compounds 2 and 1 (each within the scatter of the next); then compound 3.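

Lengthening the chain on the sulfur is not a neutral change: going from allylsulfanyl to hexylsulfanyl gives a 7.1-fold higher number from compound 2 to compound 3 (0.85 log units; beyond the scatter) in this assay and is the first step here to lie beyond the scatter. Against iodo on the aromatic carbon, hexylsulfanyl also gives a 3.8-fold higher number from compound 1 to compound 3 (0.58 log units; beyond the scatter) even though allylsulfanyl and iodo could not be told apart, so at this carbon the length of the sulfur chain decides whether a difference from iodo can be seen at all. Nothing on hand tells why the longer chain goes with weaker inhibition.

The compounds shown carry only allyl and hexyl on the sulfur, so it stays open whether the number climbs steadily with chain length or jumps beyond a certain length, and propyl or butyl chains would help to settle this. Also open, going by these compounds, is whether a chain of similar size ending in an amine or a carboxylic acid, or a benzyl group on the sulfur, would read like hexyl or like allyl.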